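The compounds below may be only part of what the source reports. "The series", "measured", "known", "first", "only" and "open" are said of these compounds alone.

Measured in an ADME assay on microsomes from liver (Homo sapiens) for metabolic stability, read by LC-MS, using NADPH, tested at 5 uM; on this read-out lower numbers stand for a shorter-lived compound and higher numbers for a longer-lived compound:
compound 1, `NC(=O)c1cn(Cc2nnc(-c3cc(S(N)(=O)=O)c(SCc4ccccc4)cc3Cl)o2)nn1`, gives 0.435 h.
compound 2, `NS(=O)(=O)c1cc(-c2nnc(CNC(=O)c3ccccc3)o2)c(Cl)cc1SCc1ccccc1`, gives 0.187 h.
compound 3, `NS(=O)(=O)c1cc(-c2nnc(/C=C/c3ccccc3)o2)c(Cl)cc1SCc1ccccc1`, gives 0.228 h.

Compound 3 stands among the other two without a separation that counts: a 1.2-fold higher number from compound 2 to compound 3 (0.09 log units; within the scatter) and a 1.9-fold lower number from compound 1 to compound 3 (0.28 log units; within the scatter) both fall within the scatter, and only a 2.3-fold lower number from compound 1 to compound 2 (0.37 log units; beyond the scatter) exceeds it. Compound 4, `NS(=O)(=O)c1cc(-c2nnc(/C=C/c3c(Cl)cccc3Cl)o2)c(Cl)cc1SCc1ccccc1`, is not yet measured; it differs from compound 3 by 2,6-dichlorophenyl in place of phenyl on a double-bonded chain carbon bound to a double-bonded chain carbon. Going by the values given here, no measured step touches this phenyl: all three steps alter the group borne by the shared core, and even the largest of them was modest. Nothing here suggests a shift beyond the scatter for this change, so the estimated step of a 1.0-fold higher number from compound 3 to compound 4 (0.00 log units; within the scatter) is expected to stay within it. Compound 4 is estimated at 0.23 h, with a range of 0.11 h to 0.46 h.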

Compound 4, half-life: 0.468 h
For compound 4 the middle estimate is 2.0-fold (0.31 log units) below the measured one, outside the stated range (above it).
By their numbers in this assay, from the lowest: compounds 2, 3, 1 and 4 (each within the scatter of the next, the first and the last beyond it).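

In this assay the phenyl on the double-bonded chain carbon proves to be a position that moves the read-out: 2,6-dichlorophenyl in its place gives a 2.1-fold higher number from compound 3 to compound 4 (0.31 log units; beyond the scatter) and so exceeds the scatter. The 2-(2,6-dichlorophenyl)ethenyl group also separates from benzamidomethyl with a 2.5-fold higher number from compound 2 to compound 4 (0.40 log units; beyond the scatter) but not from (4-carbamoyl-1H-1,2,3-triazol-1-yl)methyl with a 1.1-fold higher number from compound 1 to compound 4 (0.03 log units; within the scatter) in this comparison. No available data explain the change.

Open, as far as these compounds go, is whether both chlorines are needed or a single chlorine would give the same step. Also open, from the compounds shown here alone, is how a methoxy group or an amine on that phenyl would read.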